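This account rests on a few compounds, and the source may have more. Where it says the series, first, only, none or still open, it means among the compounds named here.

Of the compounds shown here, three have been measured. Compound 1, `COc1cc(C(=O)NNC(=S)Nc2csc(-c3ccc(C)cc3)c2)cc(OC)c1OC`, gives 31000 nM in a functional assay on MCF7 cells (Homo sapiens) for inhibition, read by colorimetric assay and MTT assay, with a stated time of 72 h; on this read-out lower numbers stand for stronger inhibition and higher numbers for weaker inhibition. Compound 2, `COc1ccc(C(=O)NNC(=S)Nc2csc(-c3ccccc3)c2)cc1`, gives 32000 nM in this assay, and compound 3, `COc1cc(OC)cc(C(=O)NNC(=S)Nc2csc(-c3ccc(C)cc3)c2)c1`, gives 26000 nM. Within the data shown here, the only single-point step among the measured compounds runs from compound 3 to compound 1: the change methoxy in place of hydrogen on an aromatic carbon gives a 1.2-fold higher number from compound 3 to compound 1 (0.08 log units; within the scatter). Compound 2 and compound 3 differ in more than one place, and the difference between their cores is not broken down here.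

The unmeasured compound 4, `COc1ccc(C(=O)NNC(=S)Nc2csc(-c3ccccc3)c2)cc1OC`, is reached from compound 2 by the change (methoxy in place of hydrogen on an aromatic carbon). Among the measured compounds shown here, this is the same kind of change as the one from compound 3 to compound 1, though the surroundings differ: in compound 4 the new methoxy sits ortho to a methoxy group and meta to a large group, whereas in compound 1 it sits ortho to two methoxy groups and para to a large group. Because the earlier step gave a 1.2-fold higher number from compound 3 to compound 1 (0.08 log units; within the scatter), compound 4 is expected to move only a 1.0-fold lower number from compound 2 to compound 4 (0.01 log units; within the scatter) from compound 2. Compound 4 is therefore estimated at about 31000 nM in this assay, likely between 15000 nM and 62000 nM.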

Compound 4, half-maximal inhibitory concentration: 21000 nM
Compound 4: the middle estimate sits 1.5-fold (0.17 log units) above what was measured; low and high end bracket the measured number.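

In this assay, methoxy in place of hydrogen on an aromatic carbon, here ortho to a methoxy group and meta to a large group, gives a 1.5-fold lower number from compound 2 to compound 4 (0.18 log units; within the scatter). Set beside the earlier step, the change shows no difference between the two cores that can be told from repeated measurements: the same change on two cores in this assay, a 1.2-fold higher number (0.08 log units; within the scatter) from compound 3 to compound 1 and a 1.5-fold lower number (0.18 log units; within the scatter) from compound 2 to compound 4, 1.8-fold (0.26 log units) apart, within the scatter of two such steps
Among these compounds, neither step lies beyond the scatter, which means the pair shows only that this change left no readable mark on either core; it does not show a real effect of the added methoxy in either direction, and it does not show how the change would behave on any other core.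

The aromatic rings of the compounds shown bear only methoxy and methyl groups, leaving open what an amine, a carboxylic acid or a chlorine atom would do in these places. Also open, going by these compounds, is whether a longer chain such as butoxy in place of methoxy would move the number in this assay beyond the scatter.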